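The compounds below may be only part of what the source reports. "The series", "measured", "known", "first", "only" and "open" are said of these compounds alone.

Compound 1, with the structure `CCCC(=O)Oc1ccc2oc(/C=C/[S+](C)[O-])cc(=O)c2c1`, was tested in a functional assay on A549 cells (Homo sapiens) for cytotoxicity, with a stated time of 48 h (on this read-out lower numbers stand for stronger inhibition and higher numbers for weaker inhibition), where compound 1 gives 2200 nM. For the measured compounds named here, the only other measured compound, compound 2, whose structure is `Cc1c(/C=C/[S+](C)[O-])oc2ccccc2c1=O`, gives in this assay a value of 1500 nM. The two numbers lie within the usual scatter of each other, so the data do not separate compound 1 from compound 2, and compound 1 cannot be placed above or below compound 2 on this read-out.

The step to compound 3, whose structure is `CCC(=O)Oc1ccc2oc(/C=C/[S+](C)[O-])cc(=O)c2c1`, concerns only the saturated chain that sits on the shared core of compound 1: hydrogen in place of methyl on a saturated chain carbon, two bonds along the chain from a carbonyl carbon. Going by the values given here, no measured pair in this set shows the effect of such a change, so there is nothing to set a direction from. A change of this small size, on a chain carbon two bonds along the chain from a carbonyl carbon, is expected to move the number by no more than the usual scatter in either direction, so the step from compound 1 to compound 3 is estimated at a 1.0-fold lower number from compound 1 to compound 3 (0.02 log units; within the scatter). Compound 3 is therefore expected to give about 2100 nM in this assay, within a range of 1000 nM to 4500 nM.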

Compound 3, half-maximal inhibitory concentration: 2400 nM
Beside the measured number, compound 3's estimate is 1.1-fold (0.06 log units) below it; the range from low to high includes it.
By their numbers in this assay, from the lowest: compounds 2, 1 and 3 (each within the scatter of the next).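

Going from propylcarbonyl to propanoyl on the shared core, which puts hydrogen in place of methyl on a saturated chain carbon, two bonds along the chain from a carbonyl carbon, gives a 1.1-fold higher number from compound 1 to compound 3 (0.04 log units; within the scatter) in this assay, and this is the only measured pair in which such a change can be read. At this place on the chain, then, the exchange of methyl for hydrogen does not separate compound 3 from compound 1 on this read-out, so the data show no dependence on this one carbon of the chain. No measurement shown bears on why the two compounds fall within the scatter of each other.

This single pair does not tell whether the read-out would stay within the scatter with a shorter chain such as acetyl, a longer chain such as pentanoyl or hexanoyl, or a chain ending in an amine or a carboxylic acid at the same place. Compound 2 differs from both of these compounds in more than one place, so the effect of the whole propylcarbonyl or propanoyl group on the shared core also remains open.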